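From 3-methylphenyl to 4-chlorophenyl: an expectation

A few compounds are considered here, and "the series" means these few. Any claim that something is new, unique, unknown or untested is made for them only; others in the source may bear on it.

Measured in a physicochemical assay for solubility, measured as kinetic solubility; a lower number here means a less soluble compound, a higher number a more soluble compound:
- Compound 1 `CNC(=O)c1cc(C(=O)N[C@H]2CC[C@H](O)CC2)c([C@@H](C)c2cccc(OC)c2)o1`: >= 113 ug/mL, a limit
- Compound 2 `CNC(=O)c1cc(C(=O)N[C@H]2CC[C@H](O)CC2)c([C@@H](C)c2cccc(C)c2)o1`: >= 172 ug/mL, a limit
- Compound 3 `CNC(=O)c1cc(C(=O)N[C@H]2CC[C@H](OC)CC2)n([C@@H](CO)c2ccccc2)n1`: >= 164 ug/mL, a limit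

In this assay compound 2 stands at >= 172 ug/mL, which is a limit. Compound 4 `CNC(=O)c1cc(C(=O)N[C@H]2CC[C@H](O)CC2)c([C@@H](C)c2ccc(Cl)cc2)o1` differs from it as follows: 4-chlorophenyl in place of 3-methylphenyl on a saturated chain carbon bound to an aromatic carbon and a saturated chain carbon. In words, 4-chlorophenyl stands in place of 3-methylphenyl on a saturated chain carbon bound to an aromatic carbon and a saturated chain carbon. Among the compounds with values here, the one measured step that bears on this is a step that the two limits leave unreadable from compound 1 to compound 2, methyl in place of methoxy on an aromatic carbon. It offers no size to carry over, so no step beyond the scatter is expected. The expected step is an at least 1.4-fold lower number from compound 2 to compound 4 (0.15 log units; that floor lies within the scatter). For compound 4 the estimate is 120 ug/mL, with an expected range of 60 ug/mL to 200 ug/mL.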

Compound 4, solubility: >= 118 ug/mL
Compound 4 was reported as a limit; the forecaster's own chance of this, stated with the estimate: 55%; the middle value does not contradict the limit.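

In this assay compound 4 gives >= 118 ug/mL, a limit. Compound 1 and compound 2 also stand as limits, so no step among these three compounds can be read. The compounds shown leave open whether 4-chlorophenyl in place of 3-methylphenyl changes solubility at all.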